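Allyl to pyridylmethyl thioether on the compound 2 series

The source may hold more compounds than are shown below. What is called first, only, known or untested is meant among the compounds shown, and "the series" means these compounds.

Compound 1 `CSc1nc(N)nc2c1ncn2[C@@H]1C[C@H](O)[C@@H](CO)O1` carries a methyl on the sulfur. In a functional assay on L1210 cells (Mus musculus) for inhibition (a higher number here means that more compound is needed for the effect, a lower number that less compound is needed), compound 1 gives > 100 uM, which is a limit of the assay and not a number. Compound 2 `C=CCSc1nc(N)nc2c1ncn2[C@@H]1C[C@H](O)[C@@H](CO)O1` has the same skeleton with an allyl on the sulfur. In this assay compound 2 gives > 100 uM, again a limit. Compound 3 `C=CCSc1nc(N)nc2c1ncn2[C@H]1C[C@H](O)[C@@H](CO)O1` differs from compound 2 only in configuration as drawn. In this assay compound 3 gives 3 uM. The step that the two limits leave unreadable from compound 1 to compound 2 cannot be read because both values sit at the limit (the limit of > 100 uM in this assay, at which 2 of the 3 values shown sit). The step of an at least 33-fold lower number from compound 2 to compound 3 (1.52 log units; beyond the scatter) rests on (the fact that compounds 2 and 3 differ only in the configuration as drawn). Compound 2 thus stands at the limit, next to compound 1 in that respect, while only compound 3 gives a number.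

Compound 4 `Cc1cccc(CSc2nc(N)nc3c2ncn3[C@@H]2C[C@H](O)[C@@H](CO)O2)n1` is not yet measured. Relative to compound 2 the change is 6-methylpyridin-2-yl in place of vinyl on a saturated chain carbon bound to a sulfur. Neither measured step bears on this exchange: the step from compound 1 to compound 2, the only one at the same position, is unreadable, and the step from compound 2 to compound 3 concerns configuration, not the sulfur substituent. Compound 4 keeps the configuration of compound 2, whose value is a limit, so no step beyond the scatter can be predicted. For compound 4 the expected step is a number no higher from compound 2 to compound 4 (the limit leaves the size open), with wide uncertainty. Compound 4 is expected to give 100 uM in this assay, within 20 uM to 300 uM, and most likely again a limit.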

Compound 4, concentration for half-maximal effect: 72 uM
The estimate for compound 4 lay 1.4-fold (0.14 log units) above the measured number, within the range that was stated.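

In this assay compound 4 gives 72 uM. The configuration of compound 2 therefore does not by itself hold every sulfur substituent in this series at the assay limit. The exchange of vinyl for 6-methylpyridin-2-yl on the saturated chain carbon bound to the sulfur gives an at least 1.3-fold lower number from compound 2 to compound 4 (0.14 log units; that floor lies within the scatter), and the same group in place of hydrogen gives an at least 1.3-fold lower number from compound 1 to compound 4 (0.14 log units; that floor lies within the scatter). The real size of either step stays unknown, and neither can be said to go beyond the scatter, because each starts from a limit and not from a number: the limit of > 100 uM in this assay, at which 2 of the 4 values shown sit.

Open, as far as these compounds go, is what a plain benzyl or an unsubstituted pyridin-2-ylmethyl on the sulfur would give in this assay, which would separate the contribution of the ring nitrogen from that of the methyl on the ring. Also open, from the compounds shown here alone, is whether (6-methylpyridin-2-yl)methyl keeps or changes the value when it is carried over to the configuration of compound 3, which gives 3 uM with allyl on the sulfur.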